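The source may hold more compounds than are shown below. What is called first, only, known or untested is meant among the compounds shown, and "the series" means these compounds.

Measured in a functional assay (Nicotiana tabacum); on this read-out higher numbers stand for weaker inhibition and lower numbers for stronger inhibition:
Compound 1 `CNc1nc(SC)nc2ncccc12`: 2920 nM
Compound 2 `CCCCNc1nc(SC)nc2ncccc12`: 270 nM
Compound 3 `CCCCCCNc1nc(SC)nc2ncccc12`: 3330 nM

Compound 3 sits level with compound 1, within the scatter, and well above compound 2, which shows the strongest inhibition of the three. Compound 4 `CCCCCCCNc1nc(SC)nc2ncccc12` differs from compound 3 by one change: methyl in place of hydrogen on a saturated chain carbon, six bonds along the chain from a nitrogen on an aromatic ring. For the measured compounds named here, the closest precedent is the ethyl addition a 12-fold higher number from compound 2 to compound 3 (1.09 log units; beyond the scatter). The propyl addition an 11-fold lower number from compound 1 to compound 2 (1.03 log units; beyond the scatter) went the other way, and the pentyl addition a 1.1-fold higher number from compound 1 to compound 3 (0.06 log units; within the scatter) left the number unmoved, so the trend is not uniform. Only one carbon enters here, so a small rise is expected in this assay, possibly within the scatter. The expected step is a 1.8-fold higher number from compound 3 to compound 4 (0.26 log units; within the scatter). For compound 4 the estimated value is 6000 nM, with an expected range of 2000 nM to 20000 nM.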

Compound 4, half-maximal inhibitory concentration: 4070 nM
Estimate against measurement, compound 4: 1.5-fold (0.17 log units) above; the measured number falls inside the stated range.
By their numbers in this assay, from the lowest: compound 2; then compounds 1, 3 and 4 (each within the scatter of the next).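

In this assay, methyl on a saturated chain carbon, six bonds along the chain from a nitrogen on an aromatic ring, gives a 1.2-fold higher number from compound 3 to compound 4 (0.09 log units; within the scatter), so this extension leaves the number unmoved, unlike the large rise on reaching compound 3. The stronger inhibition of compound 2 stays lost, with a 15-fold higher number from compound 2 to compound 4 (1.18 log units; beyond the scatter), while the long chain remains level with the short one, with a 1.4-fold higher number from compound 1 to compound 4 (0.14 log units; within the scatter). No measured evidence explains this flat stretch. From the compounds shown here alone, whether a longer chain would stay level remains open, as does whether a branched chain or a phenyl ring could restore the inhibition of compound 2.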